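Taking the cyano group off compound 1

A few compounds are considered here, and "the series" means these few. Any claim that something is new, unique, unknown or untested is made for them only; others in the source may bear on it.

For the measured compounds named here, in an ADME assay on microsomes from liver (Mus musculus) for metabolic stability, read by LC-MS, using NADPH, tested at 1 uM (a lower number here means that the compound disappears faster, a higher number that the compound lasts longer), compound 1 `Cc1cnc(NC(=O)CCCOc2cccc(C#N)c2)s1` gives 0.0667 h, the only actual number so far. Compound 2 `Cc1cnc(NC(=O)CCCOc2cccc(Cl)n2)s1` reads < 0.0334 h, which is a limit of the assay and not a number. Compound 3 `Cc1cnc(NC(=O)CCCOc2ccccc2)s1` differs from compound 1 by a single change, hydrogen in place of cyano on an aromatic carbon. Going by the values given here, no measured step bears on this change. No shift beyond the scatter is expected in this assay. The expected step is a 1.2-fold lower number from compound 1 to compound 3 (0.08 log units; within the scatter). For compound 3 the estimate is 0.055 h, with an expected range from 0.03 h to 0.12 h.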

Compound 3, half-life: 0.0333 h
Beside the measured number, compound 3's estimate is 1.7-fold (0.22 log units) above it; the range from low to high includes it.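

In this assay, for the compounds shown here, the first readable step at this position, hydrogen in place of cyano on an aromatic carbon, is a 2.0-fold lower number from compound 1 to compound 3 (0.30 log units; within the scatter). The cyano group therefore shows no effect beyond the scatter at this place. Compound 2 stands as a limit of the assay and not a number, so no step to it can be read: the limit of < 0.0334 h in this assay, at which 1 of the 3 values shown sits.

Open, on these data alone, is whether an amine or a carboxylic acid on this aromatic carbon would move the half-life beyond the scatter. As far as these compounds go, the effect of a longer chain in the core of compound 1 is also open.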